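A few compounds are considered here, and "the series" means these few. Any claim that something is new, unique, unknown or untested is made for them only; others in the source may bear on it.

Of the compounds shown here, two have been tested so far in an ADME assay on A549 cells (Homo sapiens) for cytotoxicity, read by MTT assay, with a stated time of 72 h; a higher number here means a weaker inhibitor, a lower number a stronger inhibitor. Compound 1 `O=C(NNC(=O)c1ccccc1Br)c1ccc(-n2cccc2)cc1` gives 201000 nM in this assay. Compound 2 `CC(=O)N1N=C(c2ccc(-n3c(C)ccc3C)cc2)OC1c1ccccc1[N+](=O)[O-]` gives 182000 nM in this assay. Compound 2 has the lower of the two numbers, but its gap to compound 1 lies within the usual scatter of repeated measurements, so the two cannot be told apart on these data; both are weak inhibitors of the growth of this cell line.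

The next compound, compound 3 `CC(=O)N1N=C(c2ccc(-n3c(C)ccc3C)cc2)OC1c1ccc(O)cc1`, keeps the core of compound 2 and changes one group: 4-hydroxyphenyl in place of 2-nitrophenyl on a saturated ring carbon. Among the compounds with values here, no step between two measured compounds is known here, so nothing measured shows how this kind of change plays out. Within the data shown here, the only guide is that compound 1, at 201000 nM, and compound 2, at 182000 nM, are both weak. The step is therefore expected to be small, a 1.1-fold higher number from compound 2 to compound 3 (0.04 log units; within the scatter), with no direction that rises above the scatter. Compound 3 is expected to give about 200000 nM in this assay, within a range from 90000 nM to 450000 nM.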

Compound 3, half-maximal inhibitory concentration: 190000 nM
Compound 3: the middle estimate sits 1.1-fold (0.02 log units) above what was measured; the range from low to high includes it.
By their numbers in this assay, from the lowest: compounds 2, 3 and 1 (each within the scatter of the next).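

In this assay, putting 4-hydroxyphenyl in place of 2-nitrophenyl on the saturated ring carbon gives a 1.0-fold higher number from compound 2 to compound 3 (0.02 log units; within the scatter). Within the data shown here, this is the first measured step at this position, and it shows that exchanging these two substituted phenyl groups leaves compound 2 and compound 3 indistinguishable, even though the entering group carries a hydrogen-bond donor and the leaving group does not. Nothing measured here explains why the two groups give such similar numbers.

From the compounds shown here alone, both groups at this position are substituted phenyl rings, so it remains open whether a group without an aromatic ring, such as a short alkyl chain, or a phenyl ring bearing an amine or a carboxylic acid, would give a step beyond the scatter. The acetyl group on the neighbouring ring nitrogen is also the same in compound 2 and compound 3, which leaves open what a longer acyl chain or a plain hydrogen at that atom would do to the number.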